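The compounds below may be only part of what the source reports. "The series", "measured", "known", "first", "only" and "open" are said of these compounds alone.

Compound 1 `CCCCCc1ccc(-c2cn(C/C=C3\OC(=O)C(OCc4ccccc4)=C3OCc3ccccc3)nn2)cc1` and compound 2 `CC(C)(C)OC(=O)N1CCN(C(=S)SCc2cn(C[C@H](O)[C@H]3OC(=O)C(OCc4ccccc4)=C3OCc3ccccc3)nn2)CC1` share their core with compound 3 `CCCCCCCCCCc1cn(C[C@H](O)[C@H]2OC(=O)C(OCc3ccccc3)=C2OCc2ccccc2)nn1`. In a functional assay on MCF7 cells (Homo sapiens) for antiproliferative activity, read by MTT assay, with a stated time of 72 h (a higher number here means a weaker inhibitor, a lower number a stronger inhibitor), compound 1 reaches only the assay limit, > 100000 nM. Compound 2 likewise gives only a limit, > 100000 nM. Among the measured compounds shown here, compound 3 gives 80 nM, the only true number among the three. The two others sit at the limit of > 100000 nM in this assay, at which 2 of the 3 values shown sit. Compound 4 `O=C1O[C@H]([C@@H](O)Cn2ccnn2)C(OCc2ccccc2)=C1OCc1ccccc1` differs from compound 3 in one place: hydrogen in place of decyl on an aromatic carbon. For the measured compounds named here, no measured pair here shows a change of this kind, so the size of the step cannot be read from the data. With the decyl gone, a large loss of potency is expected, a 380-fold higher number from compound 3 to compound 4 (2.57 log units; beyond the scatter). Compound 4 is therefore estimated at 30000 nM, with a plausible range from 5000 nM to 100000 nM.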

Compound 4, half-maximal inhibitory concentration: > 100000 nM
Compound 4: a limit, no number; the forecaster's own chance of this, stated with the estimate: 40%; middle value at least 3.3-fold (0.52 log units) away from the limit.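

On this core, the aromatic carbon bearing the decyl group now has a direct reading: in this assay, replacing decyl with hydrogen gives an at least 1200-fold higher number from compound 3 to compound 4 (3.09 log units; beyond the scatter). Among the compounds shown, the activity of compound 3 therefore depends on having decyl rather than hydrogen at this position. Compound 4 gives only a limit, so the step is a minimum, and its true size cannot be read: the limit of > 100000 nM in this assay, at which 3 of the 4 values shown sit.

Going by these compounds, how much of the chain is needed remains open. A hexyl chain, a longer chain or an amine at this carbon could either keep or lose the potency.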